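Adding Isopropyl to the Ring of Compound 2

The source may report more compounds than this note shows. Statements on the series, on what has been measured and on what is new or still open speak of the compounds shown alone.

Compound 2 `CC(C)(C)OC(=O)/C=C1/C(=O)Nc2ccccc21` is one of three compounds tested in a functional assay on HL-60 cells (Homo sapiens) for cytotoxicity, read by CCK-8 assay, with a stated time of 72 h; on this read-out lower numbers stand for stronger inhibition and higher numbers for weaker inhibition. In this assay compound 2 gives 2450 nM. Compound 1 `CCOC(=O)/C=C1/C(=O)Nc2ccccc21` gives 4830 nM, and the change from compound 1 to compound 2 is tert-butyl in place of ethyl on an oxygen next to a carbonyl group, with a 2.0-fold lower number from compound 1 to compound 2 (0.29 log units; within the scatter). Compound 3 `CN1C(=O)/C(=C/C(=O)OC(C)(C)C)c2ccccc21` gives 2760 nM, and the change from compound 2 to compound 3 is methyl in place of hydrogen on an amide-type nitrogen in a ring, with a 1.1-fold higher number from compound 2 to compound 3 (0.05 log units; within the scatter). Compound 2 has the lowest of the three numbers, yet both of its neighbours lie within the scatter of it, so no order among the three can be read from these values.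

Compound 4 `CC(C)c1ccc2c(c1)/C(=C\C(=O)OC(C)(C)C)C(=O)N2` has not yet been measured. It differs from compound 2 in one place: isopropyl in place of hydrogen on an aromatic carbon. Neither of the two measured steps touches an aromatic carbon of the fused ring system; both concern the ester and the ring nitrogen, and both stayed within the scatter. Going by the values given here, there is therefore no measured step that bears on this change, and nothing in the data points to a shift beyond the scatter in either direction. Compound 4 is accordingly expected to give a number close to that of compound 2 in this assay, with a step of a 1.0-fold higher number from compound 2 to compound 4 (0.01 log units; within the scatter). The estimate for compound 4 is 2500 nM, within a range from 900 nM to 7000 nM.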

Compound 4, half-maximal inhibitory concentration: 5290 nM
The estimate for compound 4 lay 2.1-fold (0.33 log units) below the measured number; the range from low to high includes it.
By their numbers in this assay, from the lowest: compounds 2, 3, 1 and 4 (each within the scatter of the next, the first and the last beyond it).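

In this assay the isopropyl change gives a 2.2-fold higher number from compound 2 to compound 4 (0.33 log units; beyond the scatter) and is the only single change shown that goes beyond the scatter, although the step is modest. The two earlier steps, at the ester and at the ring nitrogen, both stayed within the scatter, so this aromatic carbon is the one place in the series where a change of one group registers, and it does so in the direction of weaker inhibition. No measured information is available to explain this step.

The compounds shown leave open whether the step belongs to isopropyl itself or would appear with any group on this aromatic carbon, as only hydrogen and isopropyl are seen there, and a methyl, a methoxy group or an amine at the same place would begin to separate these possibilities. They also leave open whether isopropyl would give a similar step on the core of compound 1 or compound 3, where the ester or the ring nitrogen differs from that of compound 2.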